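Chloro in Place of Hydrogen on a Thiazolotriazole Core

A few compounds are considered here, and "the series" means these few. Any claim that something is new, unique, unknown or untested is made for them only; others in the source may bear on it.

Measured so far:
compound 1, `c1ccc(-c2nc3sc(-c4ccccc4)cn3n2)cc1`: 33%
compound 2, `C/C(=N/O)c1ccc(NC(=O)Cn2nc(C(F)(F)F)nc2N)cc1`: 5.39%
compound 3, `COc1cc(-c2nc3sc(-c4ccccc4)cn3n2)cc(OC)c1OC`: 31%

In a functional assay on UACC-62 cells (Homo sapiens) for inhibition, read by sulforhodamine B assay, with a stated time of 48 h, tested at 10 uM (on this read-out higher numbers stand for more inhibition of growth at the one concentration tested and lower numbers for less inhibition of growth), compound 1 gives 33%, the highest of the three numbers. The number for compound 3, 31%, lies within the usual scatter of it, so the two cannot be told apart. Compound 2, with 5.39%, lies well beyond the scatter below compound 1.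

Compound 4, `Clc1ccc(-c2cn3nc(-c4ccccc4)nc3s2)cc1`, differs from compound 1 in one place: chloro in place of hydrogen on an aromatic carbon. For the measured compounds named here, no measured pair shows this change, so its effect is unknown. Because compound 3 shows 31% after a different substitution on the core, small changes of this kind appear to leave the read-out roughly where it is. Compound 4 is therefore expected to show a step of a number 2 percentage points higher from compound 1 to compound 4 (within the scatter), none beyond the scatter. The estimated value of compound 4 is 35%, between 15% and 55%.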

Compound 4, percent growth inhibition at one concentration: 18%
Compound 4: middle estimate off by 17 percentage points, on the high side; measured number inside the range.
By their numbers in this assay, from the lowest: compound 2; then compound 4; then compounds 3 and 1 (each within the scatter of the next).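

In this assay, for the compounds shown here, the change from phenyl to 4-chlorophenyl gives a number 15 percentage points lower from compound 1 to compound 4 (beyond the scatter) and so provides the first comparison here of two compounds that differ in one place. It shows that this position on the shared core is sensitive: a single chloro, para to a large group, is enough to lower growth inhibition. No measured evidence here explains the drop.

On these data alone, it remains open whether this loss is specific to chloro or would also follow from another group at the same carbon, such as fluoro, methyl or an amine. As far as these compounds go, how the other phenyl ring responds to the same change also remains open.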